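Propyl to allyl carbamate on the selenocyanate aryl series

The source may report more compounds than this note shows. Statements on the series, on what has been measured and on what is new or still open speak of the compounds shown alone.

Two compounds of this series have numbers in a functional assay on CCRF-CEM cells (Homo sapiens) for cytotoxicity, read by MTT assay, with a stated time of 72 h; a lower number here means a stronger inhibitor of growth, a higher number a weaker inhibitor of growth. Compound 1 `CCCOC(=O)Nc1ccc([Se]C#N)cc1` gives 9300 nM in this assay, the lower of the two. Within the data shown here, compound 2 `CCOC(=O)Nc1ccc([Se][Se]c2ccc(NC(=O)OCC)cc2)cc1`, a diselenide carrying an ethyl carbamate on each ring, gives 24600 nM in this assay, a higher number that lies beyond the scatter of compound 1; the two differ in more than one place, so no single step between them can be read.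

Compound 3 `C=CCOC(=O)Nc1ccc([Se]C#N)cc1` has not yet been measured. It differs from compound 1 by vinyl in place of ethyl on a saturated chain carbon bound to an oxygen next to a carbonyl group, that is, the carbamate chain goes from propoxy to allyloxy while the selenocyanate and the shared core stay as they are. Nothing in the measured pair speaks to this change, and a change of this kind at the far end of the carbamate chain is expected to leave the growth inhibition about where it is: the step from compound 1 to compound 3 is estimated as a 1.0-fold lower number from compound 1 to compound 3 (0.01 log units; within the scatter), with no direction beyond the scatter expected. Compound 3 is therefore estimated at 9000 nM in this assay, within a range from 4000 nM to 20000 nM.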

Compound 3, concentration for 50% growth inhibition: 9200 nM
For compound 3 the middle estimate is 1.0-fold (0.01 log units) below the measured one, and the stated range covers the measured number.
By their numbers in this assay, from the lowest: compounds 3 and 1 (each within the scatter of the next); then compound 2.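

Among these compounds, compound 3 supplies the first step that can be read at a single place: in this assay, the carbamate chain going from propoxy to allyloxy gives a 1.0-fold lower number from compound 1 to compound 3 (0.00 log units; within the scatter). On a saturated chain carbon bound to an oxygen next to a carbonyl group, vinyl in place of ethyl therefore leaves the reading unchanged within the scatter, so for this one pair the added double bond outside aromatic rings has no visible effect on growth inhibition. No supporting measurement is available to explain why the two carbamates read alike.

The compounds shown leave open whether a longer chain, a branched chain such as isopropyl, or a benzyl group at the end of the carbamate would also stay within the scatter, or whether a terminal amine or carboxylic acid there would shift the number. Among the compounds shown here, compound 2 differs from both compound 1 and compound 3 in more than one place, so no step to it can be read, and the effect of a diselenide in place of a selenocyanate remains unresolved until a diselenide carrying the propyl carbamate can be compared with compound 1.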